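Swapping sec-butyl for cyclopropylmethyl on the shared core

The source may hold more compounds than are shown below. What is called first, only, known or untested is meant among the compounds shown, and "the series" means these compounds.

Measured compounds:
compound 1 `CC[C@H](C)[C@@H]1C(=O)N[C@H](C2Cc3ccccc3C2)C(=O)N1[C@@H](C(=O)N1CCOCC1)c1ccc(C)nc1`: > 268 ug/mL
compound 2 `COc1ccc([C@H](C(=O)N(C)C)N2C(=O)[C@@H](C3Cc4ccccc4C3)NC(=O)[C@H]2CC(C)C)cn1`: 216 ug/mL
compound 3 `CC(C)C[C@@H]1C(=O)N[C@H](C2Cc3ccccc3C2)C(=O)N1[C@@H](C(=O)N(C)C)c1ccc(N(C)C)nc1`: 233 ug/mL

In a physicochemical assay for solubility, read by HPLC (on this read-out lower numbers stand for lower solubility and higher numbers for higher solubility), compound 1 gives > 268 ug/mL, which is a limit of the assay and not a number, as noted in the limit of > 268 ug/mL in this assay, at which 1 of the 3 values shown sits. Compound 2 gives 216 ug/mL and compound 3 gives 233 ug/mL, and a 1.1-fold higher number from compound 2 to compound 3 (0.03 log units; within the scatter). Compound 4 `Cc1ccc([C@H](C(=O)N2CCOCC2)N2C(=O)[C@@H](C3Cc4ccccc4C3)NC(=O)[C@H]2CC2CC2)cn1` differs from compound 1 by cyclopropylmethyl in place of sec-butyl on a saturated ring carbon. For the measured compounds named here, the one measured step changes a group on an aromatic carbon, so it does not bear on this change at a saturated ring carbon. Going by the values given here, with no matching step, a move of no more than the scatter is expected, so compound 4 is estimated at 240 ug/mL, between 110 ug/mL and 400 ug/mL, which means a step of an at least 1.1-fold lower number from compound 1 to compound 4 (0.04 log units; that floor lies within the scatter) from compound 1.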

Compound 4, solubility: > 258 ug/mL
Compound 4 was reported as a limit; the forecaster's own chance of this, stated with the estimate: 45%; at least 1.0-fold (0.03 log units) between middle value and limit.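

Compound 1 and compound 4 are both reported as limits and not as numbers, and the step between them cannot be read. The compounds shown leave open whether cyclopropylmethyl in place of sec-butyl changes solubility at all.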